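Swapping Methoxy for Ethyl on an Aromatic Ring

The compounds below may be only part of what the source reports. "The series", "measured", "known", "first", "only" and "open" are said of these compounds alone.

Of the compounds shown here, three sharing one core have been measured in a functional assay on HL-60 cells (Homo sapiens) for cytotoxicity, read by WST assay, with a stated time of 48 h; on this read-out lower numbers stand for an effect already at smaller amounts and higher numbers for an effect only at larger amounts of compound. Compound 1 (`O=C1OC[C@H](Cc2ccccc2)[C@H]1Cc1ccc(Cl)c(Cl)c1`) gives 19000 nM, compound 2 (`Cc1cccc(C[C@H]2COC(=O)[C@@H]2Cc2ccc(Cl)c(Cl)c2)c1`) gives 22000 nM, and compound 3 (`COc1ccc(C[C@H]2COC(=O)[C@@H]2Cc2ccc(Cl)c(Cl)c2)cc1`) gives 37000 nM. Compound 3 does not stand apart from the other two: a 1.7-fold higher number from compound 2 to compound 3 (0.23 log units; within the scatter) and a 1.9-fold higher number from compound 1 to compound 3 (0.29 log units; within the scatter) are both small enough to be ordinary variation between repeated measurements.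

Compound 4 (`CCc1ccc(C[C@H]2COC(=O)[C@@H]2Cc2ccc(Cl)c(Cl)c2)cc1`) has not yet been measured. It has ethyl in place of methoxy on an aromatic carbon, para to a large group: ethyl in place of methoxy on an aromatic carbon.

Among the compounds with values here, no measured compound carries ethyl, so the evidence is indirect. Two measured changes touch an aromatic carbon of this series. Methyl in place of hydrogen gave a 1.2-fold higher number from compound 1 to compound 2 (0.06 log units; within the scatter), and methoxy in place of hydrogen gave a 1.9-fold higher number from compound 1 to compound 3 (0.29 log units; within the scatter). Neither change moved the number beyond the scatter, so these three compounds offer no reason to expect a large shift in this assay. The expected step is a 1.4-fold lower number from compound 3 to compound 4 (0.15 log units; within the scatter), with no change beyond the scatter anticipated in either direction. Compound 4 is estimated at 26000 nM, with an expected range from 13000 nM to 52000 nM.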

Compound 4, half-maximal effective concentration: 16000 nM
Estimate against measurement, compound 4: 1.6-fold (0.21 log units) above; the measured number falls inside the stated range.
By their numbers in this assay, from the lowest: compounds 4, 1, 2 and 3 (each within the scatter of the next, the first and the last beyond it).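

In this assay, replacing methoxy with ethyl at this aromatic carbon, para to a large group, gives the only step among these compounds that lies beyond the scatter: a 2.3-fold lower number from compound 3 to compound 4 (0.36 log units; beyond the scatter), a modest change. Ethyl does not stand apart from the other compounds, since a 1.2-fold lower number from compound 1 to compound 4 (0.07 log units; within the scatter) and a 1.4-fold lower number from compound 2 to compound 4 (0.14 log units; within the scatter) are both within the scatter, so the separation appears only in the direct comparison of ethyl with methoxy and not against the compound with hydrogen at this position. The swap removes one oxygen and its hydrogen-bond acceptor, but no available measurement shows whether that accounts for the step, and nothing else shown here offers an explanation.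

The compounds shown leave open how a longer chain such as propyl, or an amine or a carboxylic acid, would read at this same aromatic carbon. They also leave open whether the step between ethyl and methoxy would persist on a different core or in a different cell line.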